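The compounds below may be only part of what the source reports. "The series", "measured", "known", "first", "only" and "open" are said of these compounds alone.

Compound 1 `CCCNCc1nccn1Nc1nc(C)nc2c1c(C)nn2-c1ccc(OC)cc1C` gives 400 nM in a functional assay on CHO cells for antagonist activity at corticotropin-releasing factor receptor 1 (Homo sapiens), read by cAMP accumulation; a higher number here means a weaker inhibitor, a lower number a stronger inhibitor.
Compound 2 `CC[C@@H](COC)Nc1nc(C)nc2c1c(C)nn2-c1ccc(OC)cc1C` gives 135 nM.
Compound 3 `CC[C@H](COC)Nc1nc(C)nc2c1c(C)nn2-c1ccc(OC)cc1C` gives 210 nM.

Compound 3 stands second highest of the three numbers in this assay; its nearest neighbour lies at a 1.6-fold higher number from compound 2 to compound 3 (0.19 log units; within the scatter) and its furthest at a 1.9-fold lower number from compound 1 to compound 3 (0.28 log units; within the scatter), both within the scatter. Compound 4 `CCC[C@@H](CO)Nc1nc(C)nc2c1c(C)nn2-c1ccc(OC)cc1C` differs from compound 3 by 1-(hydroxymethyl)butyl in place of 1-(methoxymethyl)propyl on a nitrogen on an aromatic ring. Among the measured steps, a 1.6-fold higher number from compound 2 to compound 3 (0.19 log units; within the scatter) rests only on (the fact that compounds 2 and 3 differ only in the configuration as drawn), while a 3.0-fold lower number from compound 1 to compound 2 (0.47 log units; beyond the scatter) and a 1.9-fold lower number from compound 1 to compound 3 (0.28 log units; within the scatter) exchange a whole ring-bearing group; none of them tests the methoxymethyl-to-hydroxymethyl exchange itself. Compound 4 is therefore expected to show no step beyond the scatter, a 1.0-fold higher number from compound 3 to compound 4 (0.02 log units; within the scatter). Compound 4 is estimated at 220 nM, within a range from 80 nM to 650 nM.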

Compound 4, inhibition constant: 574 nM
Beside the measured number, compound 4's estimate is 2.6-fold (0.42 log units) below it; low and high end bracket the measured number.
By their numbers in this assay, from the lowest: compounds 2, 3, 1 and 4 (each within the scatter of the next, the first and the last beyond it).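

Rearranging the same atoms from 1-(methoxymethyl)propyl to 1-(hydroxymethyl)butyl on this nitrogen moves the number beyond the scatter, which the configuration change between the two methoxymethyl compounds did not do: a 2.7-fold higher number from compound 3 to compound 4 (0.44 log units; beyond the scatter), and a 4.3-fold higher number from compound 2 to compound 4 (0.63 log units; beyond the scatter). The 1-(hydroxymethyl)butyl group and the imidazole-bearing group remain within the scatter of each other: a 1.4-fold higher number from compound 1 to compound 4 (0.16 log units; within the scatter). Nothing measured here explains the step. From the compounds shown here alone, the change swaps methyl ether for hydroxyl and lengthens the chain together, so their shares remain unknown. A 1-(hydroxymethyl)propyl or 1-(methoxymethyl)butyl group would separate them.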